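A few compounds are considered here, and "the series" means these few. Any claim that something is new, unique, unknown or untested is made for them only; others in the source may bear on it.

Measured in a functional assay on A2780 cells (Homo sapiens) for antiproliferative activity, read by MTT assay, with a stated time of 48 h; on this read-out higher numbers stand for weaker inhibition of growth and lower numbers for stronger inhibition of growth:
Compound 1 `CCCOC(=O)N1N=C(c2ccccc2)CC1c1cc(OC)c(OC)c(OC)c1`: 10800 nM
Compound 2 `CCOC(=O)N1N=C(c2cccc(OC)c2)CC1c1cc(OC)c(OC)c(OC)c1`: 7300 nM

In this assay, compound 2 at 7300 nM lies within the scatter of compound 1 at 10800 nM. Compound 3 `CCCOC(=O)N1N=C(c2cccc(OC)c2)CC1c1cc(OC)c(OC)c(OC)c1` differs from compound 2 by methyl in place of hydrogen on a saturated chain carbon, two bonds along the chain from an oxygen next to a carbonyl group, read one bond further out as ethoxy to propoxy. Among the compounds with values here, no measured step isolates this change, and no shift beyond the scatter is expected in this assay. The estimated 1.1-fold higher number from compound 2 to compound 3 (0.04 log units; within the scatter) is expected to remain within the scatter. Compound 3 is expected at 8000 nM, with an estimated range of 3500 nM to 18000 nM.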

Compound 3, concentration for 50% growth inhibition: > 10000 nM
Compound 3 gave a limit, no number; the forecaster's own chance of this, stated with the estimate: 5%; middle value at least 1.2-fold (0.09 log units) away from the limit.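

In this assay, compound 3 gives > 10000 nM, which is a limit and not a number. Ethoxy to propoxy at this position gives an at least 1.3-fold higher number from compound 2 to compound 3 (0.13 log units; that floor lies within the scatter), so this change now has a floor for its size, but that floor does not show a shift beyond the scatter, and the step with compound 1 cannot be read. The limit also restricts what can be read at this end of the series: the limit of > 10000 nM in this assay, at which 1 of the 3 values shown sits.

On these data alone, the actual size of the ethoxy to propoxy step remains open. Also open, as far as these compounds go, is how a longer chain or an amine on that saturated chain carbon would read in this assay.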